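The source may report more compounds than this note shows. Statements on the series, on what has been measured and on what is new or still open speak of the compounds shown alone.

Working notes on the series.

Compound 1 `CC(C)(C)N(NC(=O)c1ccccc1)C(=O)c1ccccc1F` is the reference point. For the measured compounds named here, in an assay on cells for agonist activity at ecdysone receptor (Bombyx mori), read by a luciferase reporter, with a stated time of 24 h (a higher number here means that more compound is needed for the effect, a lower number that less compound is needed), compound 1 gives 309 nM, the lowest of the two numbers measured so far. Going by the values given here, the only other measured member is compound 2 `CC(C)(C)N(NC(=O)c1ccccc1)C(=O)c1ccccc1C(F)(F)F`, which in this assay gives 631 nM; the change is a 2.0-fold higher number from compound 1 to compound 2 (0.31 log units; beyond the scatter), a single substitution on the same aromatic carbon that is in question here.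

Compound 3 `Cc1ccccc1C(=O)N(NC(=O)c1ccccc1)C(C)(C)C` is not yet measured. It differs from compound 1 by methyl in place of fluoro on an aromatic carbon: the group sits on an aromatic carbon of a six-membered aromatic ring of carbon only, ortho to a large group, and the cut one bond further out reads 2-fluorophenyl to 2-methylphenyl.

Among the compounds with values here, the single step that bears on this position, from compound 1 to compound 2, was modest and ran toward a higher number. Methyl in place of fluoro is a different exchange at that carbon, and the series holds no step for it. Within the data shown here, the expectation is therefore a small move in this assay, if any beyond the scatter, leaning toward a higher number as the one comparable step did.

The estimated step from compound 1 to compound 3 is a 1.3-fold higher number from compound 1 to compound 3 (0.11 log units; within the scatter). For compound 3 the expected value in this assay is 400 nM, with a range from 150 nM to 1100 nM.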

Compound 3, half-maximal effective concentration: 224 nM
For compound 3 the middle estimate is 1.8-fold (0.25 log units) above the measured one; measured number inside the range.
By their numbers in this assay, from the lowest: compounds 3 and 1 (each within the scatter of the next); then compound 2.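

Methyl and fluoro on this aromatic carbon, ortho to a large group, cannot be told apart in this assay: the exchange gives a 1.4-fold lower number from compound 1 to compound 3 (0.14 log units; within the scatter) and leaves the two groups level, so the earlier rise seen with trifluoromethyl does not extend to every replacement of fluoro here. Of the three groups, trifluoromethyl alone stands apart, with a 2.8-fold lower number from compound 2 to compound 3 (0.45 log units; beyond the scatter) as a second modest step beyond the scatter alongside the earlier 2.0-fold higher number from compound 1 to compound 2 (0.31 log units; beyond the scatter) at the same carbon. No evidence is at hand on what lies behind this reading of the three groups.

The compounds shown leave open how a chloro, a methoxy or an amino group on this carbon would read, and where the ring with only hydrogen at this carbon would fall relative to the 2-fluorophenyl and 2-methylphenyl compounds. They also leave open whether the same reading of methyl, fluoro and trifluoromethyl holds at any other carbon of this ring, as all three groups occupy a single place on the shared core.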